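A few compounds are considered here, and "the series" means these few. Any claim that something is new, unique, unknown or untested is made for them only; others in the source may bear on it.

In a functional assay on KB cells (Homo sapiens) for antiproliferative activity, read by MTT assay, with a stated time of 72 h (a lower number here means a stronger inhibitor, a higher number a weaker inhibitor), compound 1 `CN(C(=O)c1ccco1)c1ccc2[nH]c(-c3n[nH]c4ccccc34)cc2n1` gives 19400 nM and compound 2 `CN(c1ccc2[nH]c(-c3n[nH]c4ccccc34)cc2n1)S(=O)(=O)c1ccc(Cl)cc1` gives 8350 nM, the lower of the two numbers. Compound 3 `COc1ccc(OC)c(S(=O)(=O)N(C)c2ccc3[nH]c(-c4n[nH]c5ccccc45)cc3n2)c1` differs from compound 2 on a sulfonyl sulfur: 2,5-dimethoxyphenyl in place of 4-chlorophenyl on a sulfonyl sulfur. Within the data shown here, the only measured step with any bearing is the modest 2.3-fold lower number from compound 1 to compound 2 (0.37 log units; beyond the scatter), which replaced the whole (furan-2-yl)carbonyl and so shows nothing direct about this exchange. No step beyond the scatter is therefore expected in this assay. The estimated change is a 1.0-fold lower number from compound 2 to compound 3 (0.02 log units; within the scatter). For compound 3 the expected value is 8000 nM, with an estimated range from 3000 nM to 22000 nM.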

Compound 3, half-maximal inhibitory concentration: 4380 nM
Estimate against measurement, compound 3: 1.8-fold (0.26 log units) above; the range from low to high includes it.
By their numbers in this assay, from the lowest: compounds 3 and 2 (each within the scatter of the next); then compound 1.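

In this assay, the change on the sulfonyl sulfur, where 4-chlorophenyl leaves and 2,5-dimethoxyphenyl enters, gives a 1.9-fold lower number from compound 2 to compound 3 (0.28 log units; within the scatter). Unlike the earlier step, which replaced the whole (furan-2-yl)carbonyl, this exchange keeps the sulfonyl and alters only its aryl group. The two numbers lie within the scatter of each other, although the entering group has more heavy atoms and two hydrogen-bond acceptors where the leaving group has none.

As far as these compounds go, whether an amine, a carboxylic acid or a plain methyl on this sulfur would give a similar number remains open. No available evidence bears on this result.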